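This account rests on a few compounds, and the source may have more. Where it says the series, first, only, none or still open, it means among the compounds named here.

The study concerns a functional assay (aorta) for inhibition, with Rattus norvegicus as the target; a higher number here means a weaker inhibitor, a lower number a stronger inhibitor. Of the compounds shown here, three have been measured. Compound 1 `CC(=O)c1ccc2c(c1)[C@@H](/N=C(\NC#N)Nc1ccccc1)[C@H](O)C(C)(C)O2` gives 4000 nM in this assay. Compound 3 `CC(=O)O[C@H]1[C@H](NC(=O)Nc2ccccc2)c2cc(C#N)ccc2OC1(C)C` gives 4400 nM. Compound 2 `CC1(C)Oc2ccc(C#N)cc2[C@@H](/N=C(\NC#N)Nc2ccccc2)[C@H]1O` gives 17000 nM, the highest of the three numbers: compound 3 lies nearest to it with a lower number, compound 1 lies furthest from it with a lower number still, and both gaps reach beyond the usual scatter, so compound 2 is the weakest inhibitor of the three.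

Compound 4 `CC1(C)C[C@H](/N=C(\NC#N)Nc2ccccc2)c2cc(C#N)ccc2O1` has not yet been measured. It differs from compound 2 by hydrogen in place of hydroxy on a saturated ring carbon. For the measured compounds named here, no pair of measured compounds shows this same change, so its effect is untested here. With nothing to lean on, a step of a 1.8-fold higher number from compound 2 to compound 4 (0.25 log units; within the scatter) towards a weaker inhibitor is expected. For compound 4 the estimate is 30000 nM, with a range from 8000 nM to 100000 nM, and a starting point this high leaves a fair chance that the assay reports only a limit.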

Compound 4, half-maximal inhibitory concentration: 14000 nM
Compound 4: middle estimate off by 2.1-fold (0.33 log units), on the high side; the measured number falls inside the stated range.
By their numbers in this assay, from the lowest: compounds 1 and 3 (each within the scatter of the next); then compounds 4 and 2 (each within the scatter of the next).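

Hydrogen in place of hydroxy on the saturated ring carbon gives the first direct reading of this position in this assay: a 1.2-fold lower number from compound 2 to compound 4 (0.08 log units; within the scatter) is all that separates the pair, and this step lies within the scatter. The hydroxy can therefore leave this carbon, which sits next to the ring atom bearing two methyl groups, without a difference that this assay can resolve, though this rests on a single pair of compounds. Nothing available here offers an explanation for this result.

Going by these compounds, it remains open whether larger or different groups at this position, such as an amine, a methoxy group or a longer chain, would also leave the number within the scatter. On these data alone, it is equally open whether the same replacement would give a comparable step on compound 1, which carries an acetyl group in place of the nitrile.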